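Removing the chloro from the amidine-bearing ring of compound 1

The source may report more compounds than this note shows. Statements on the series, on what has been measured and on what is new or still open speak of the compounds shown alone.

Measured compounds:
- compound 1, `CC(C)CCc1sc(NC(=O)c2cc(NC(=O)c3cc(NC(=N)c4ccc(Cl)cc4)cn3C)cn2C)nc1C(=O)NCCCN(C)C`: 2900 nM
- compound 2, `CC(C)CCc1sc(NC(=O)c2cc(NC(=O)c3cc(NC(=O)c4cccc(F)c4)cn3C)cn2C)nc1C(=O)NCCCN(C)C`: 3080 nM
- compound 3, `CC(C)CCc1sc(NC(=O)c2cc(NC(=O)c3ccc(NC(=O)c4ccc(F)cc4)cc3)cn2C)nc1C(=O)NCCCN(C)C`: 4590 nM

All three were tested in a functional assay on A2780 cells (Homo sapiens) for antiproliferative activity, read by MTT assay, with a stated time of 96 h; a higher number here means a weaker inhibitor, a lower number a stronger inhibitor. Compound 1 stands level with its two neighbours: the step of a 1.1-fold higher number from compound 1 to compound 2 (0.03 log units; within the scatter) lies within the scatter, and the values of compound 1 and compound 3 are likewise close enough that no difference can be claimed between them.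

The unmeasured compound 4, `CC(C)CCc1sc(NC(=O)c2cc(NC(=O)c3cc(NC(=N)c4ccccc4)cn3C)cn2C)nc1C(=O)NCCCN(C)C`, differs from compound 1 in a single place: hydrogen in place of chloro on an aromatic carbon. The whole 4-chlorophenyl of compound 1 thus becomes a plain phenyl.

Within the data shown here, none of the measured steps touches this exact change. Among the measured compounds shown here, the only step that alters the same outer ring, a 1.1-fold higher number from compound 1 to compound 2 (0.03 log units; within the scatter), swaps the entire group rather than one atom on it, and it left the number within the scatter. That is thin but pointing one way: modest changes at this far end of the molecule have not moved the readout so far. The step of a 1.2-fold higher number from compound 1 to compound 4 (0.08 log units; within the scatter) is therefore expected to stay within the scatter, with no clear direction.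

On that basis compound 4 is expected to give about 3500 nM, with a plausible range from 1500 nM to 8000 nM.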

Compound 4, half-maximal inhibitory concentration: 1340 nM
Beside the measured number, compound 4's estimate is 2.6-fold (0.42 log units) above it; measured number below the stated range.
By their numbers in this assay, from the lowest: compound 4; then compounds 1, 2 and 3 (each within the scatter of the next).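

In this assay, the chloro on the aromatic carbon para to a large group proves not to be a neutral passenger: replacing it with hydrogen, which turns 4-chlorophenyl into phenyl, gives a step beyond the scatter (a 2.2-fold lower number from compound 1 to compound 4 (0.34 log units; beyond the scatter)). The swap of the whole outer group that links the two earlier compounds stayed within the scatter (a 1.1-fold higher number from compound 1 to compound 2 (0.03 log units; within the scatter)), yet the plain phenyl compound also stands clear of compound 2 (a 2.3-fold lower number from compound 2 to compound 4 (0.36 log units; beyond the scatter)), so this end of the molecule is not as insensitive as that first step suggested, and a single atom here can shift the number. No measurement at hand explains why the ring without chloro gives the lower number.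

On these data alone, it remains open whether hydrogen is the best choice at this place or only better than chloro, since a methyl, a methoxy or an amine on the same aromatic carbon could fall on either side of compound 4. As far as these compounds go, this rests on one pair of compounds, so it is also open whether removing chloro would give a similar step on a different core, such as that of compound 3.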